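Benzyl in Place of Methyl: a Step Without Precedent

The source may report more compounds than this note shows. Statements on the series, on what has been measured and on what is new or still open speak of the compounds shown alone.

Compound 1 `CN1C(=O)C2(C(C#N)=C(N)Oc3cc4oc(-c5ccccc5)cc(=O)c4c(O)c32)c2ccccc21` in a functional assay on K562 cells (Homo sapiens) for antiproliferative activity, read by MTT assay, with a stated time of 48 h (on this read-out lower numbers stand for stronger inhibition and higher numbers for weaker inhibition), gives > 50000 nM, a limit of the assay.
Compound 2 `CN1C(=O)C2(C(C#N)=C(N)Oc3cc4oc(-c5ccccc5)cc(=O)c4c(O)c32)c2cccc(Cl)c21` in this assay gives 41400 nM.
Compound 3 `COc1ccc2c(c1)C1(C(=O)N2Cc2ccccc2)C(C#N)=C(N)Oc2cc3oc(-c4ccccc4)cc(=O)c3c(O)c21` in this assay gives > 50000 nM, again a limit of the assay.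

Among the measured compounds shown here, compound 2 thus holds the only number in this assay; the other two values are limits, as the limit of > 50000 nM in this assay, at which 2 of the 3 values shown sit, shows. Compound 4 `N#CC1=C(N)Oc2cc3oc(-c4ccccc4)cc(=O)c3c(O)c2C12C(=O)N(Cc1ccccc1)c1c(Cl)cccc12` differs from compound 2 by phenyl in place of hydrogen on a saturated chain carbon bound to an amide-type nitrogen in a ring, the same difference read one bond further out as methyl to benzyl. For the measured compounds named here, the only measured step, an at least 1.2-fold lower number from compound 1 to compound 2 (0.08 log units; that floor lies within the scatter), concerns a different change and lies within the scatter, so no measured pair covers this one. Compound 3 also carries a benzyl group and sits at a limit. For compound 4 no step beyond the scatter is expected, so a 1.1-fold higher number from compound 2 to compound 4 (0.04 log units; within the scatter) is the estimate. Compound 4 is expected at 45000 nM, between 18000 nM and 110000 nM, with a real chance that only a limit is reported.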

Compound 4, half-maximal inhibitory concentration: 47800 nM
Compound 4: middle estimate off by 1.1-fold (0.03 log units), on the low side; the range from low to high includes it.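

In this assay, among the compounds shown here, the first readable change at this position, on a saturated chain carbon bound to an amide-type nitrogen in a ring, gives a 1.2-fold higher number from compound 2 to compound 4 (0.06 log units; within the scatter). Methyl to benzyl therefore makes no measurable difference here, and the phenyl ring is tolerated without any gain in potency. Compound 1 and compound 3 stand at a limit: the limit of > 50000 nM in this assay, at which 2 of the 4 values shown sit.

Still open, going by these compounds, is whether a different group at this place, such as an amine or a carboxylic acid on a longer chain, would move the number beyond the scatter.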